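Replacing the (5-aminopentyl)amino tail with chloro

The compounds below may be only part of what the source reports. "The series", "measured", "known", "first", "only" and "open" are said of these compounds alone.

Two analogues sharing one core have been measured in an assay on Raji cells for inhibition of Monocarboxylate transporter 1 (Homo sapiens), read by MTT assay, with a stated time of 96 h; on this read-out lower numbers stand for an effect already at smaller amounts and higher numbers for an effect only at larger amounts of compound. Compound 1 `CC(C)Cc1nn(C)c(=O)c2c(SCCCO)n(Cc3ccnc(NCCCCCNC(=O)[C@@H](N)CCC(N)=O)c3)cc12` carries a (1-amino-3-carbamoylpropyl)carbonyl group on the chain amine and gives 500 nM. Compound 2 `CC(C)Cc1nn(C)c(=O)c2c(SCCCO)n(Cc3ccnc(NCCCCCN)c3)cc12` lacks that group and gives 520 nM. Within the data shown here, the only step between them, a 1.0-fold higher number from compound 1 to compound 2 (0.02 log units; within the scatter), puts the two within the scatter of one another, so compound 2 stands level with compound 1 on the numbers so far and no order can be drawn between them. Compound 3 `CC(C)Cc1nn(C)c(=O)c2c(SCCCO)n(Cc3ccnc(Cl)c3)cc12` has not been measured; it differs from compound 2 by chloro in place of (5-aminopentyl)amino on an aromatic carbon. Among the measured compounds shown here, the one measured step touches only the far end of the chain and bears on this change only loosely: it shows that the (1-amino-3-carbamoylpropyl)carbonyl group on the amine can be dropped without effect, but it says nothing about taking away the whole (5-aminopentyl)amino group. With the chain gone, a modest loss is expected in this assay, estimated as a 1.7-fold higher number from compound 2 to compound 3 (0.24 log units; within the scatter). Compound 3 is accordingly expected at about 900 nM, with a range from 250 nM to 3000 nM.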

Compound 3, half-maximal effective concentration: 1000 nM
Beside the measured number, compound 3's estimate is 1.1-fold (0.05 log units) below it; low and high end bracket the measured number.
By their numbers in this assay, from the lowest: compounds 1, 2 and 3 (each within the scatter of the next).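

In this assay, the exchange of the whole (5-aminopentyl)amino group for chloro, on the aromatic carbon next to the ring nitrogen, amounts to a 1.9-fold higher number from compound 2 to compound 3 (0.28 log units; within the scatter). The earlier step touched only the far end of the chain, whereas this one removes the chain together with the amino nitrogen that joins it to the ring, and the two numbers still cannot be told apart. For this pair, then, neither the five-carbon chain nor its terminal amine is needed to keep the read-out within the scatter, and no measurement here explains that tolerance.

The compounds shown leave open whether the read-out would also hold with a plain hydrogen, a bare amine, a methoxy group or a carboxylic acid on this carbon, or with a shorter or longer aminoalkyl chain. They also leave open whether a larger step would appear if the chloro were combined with a change elsewhere on the shared core, such as replacing the hydroxypropyl chain on sulfur with a methyl group.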